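The compounds below may be only part of what the source reports. "The series", "measured", "known", "first", "only" and "open" are said of these compounds alone.

Measured in a functional assay on HeLa S3 cells (Homo sapiens) for antiproliferative activity, read by XTT assay, with a stated time of 72 h; a lower number here means a stronger inhibitor, a higher number a weaker inhibitor:
- compound 1 `CSc1ncnc2c1c(-c1ccoc1)cn2[C@@H]1O[C@H](CO)[C@@H](O)[C@H]1O`: 5390 nM
- compound 2 `CNc1ncnc2c1c(-c1ccoc1)cn2[C@@H]1O[C@H](CO)[C@@H](O)[C@H]1O`: > 20000 nM (a limit of the assay, not a number)
- compound 3 `CN(C)c1ncnc2c1c(-c1ccoc1)cn2[C@@H]1O[C@H](CO)[C@@H](O)[C@H]1O`: 9060 nM

Among the measured compounds shown here, compound 3 gives 9060 nM, one of only two true numbers, and the gap to the other is a 1.7-fold higher number from compound 1 to compound 3 (0.23 log units; within the scatter).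

The next compound is compound 4 `CN(C)c1ncnc2c1c(-c1cc3ccccc3o1)cn2[C@@H]1O[C@H](CO)[C@@H](O)[C@H]1O`, with this change: 1-benzofuran-2-yl in place of furan-3-yl on an aromatic carbon. In words, it has 1-benzofuran-2-yl in place of furan-3-yl on an aromatic carbon.

For the measured compounds named here, none of the measured steps touches that group. All three exchange methylsulfanyl, methylamino and dimethylamino while furan-3-yl stays fixed, so they offer only a rough scale for a single change in this series. The two larger ones are an at least 3.7-fold higher number from compound 1 to compound 2 (0.56 log units; beyond the scatter) and an at least 2.2-fold lower number from compound 2 to compound 3 (0.34 log units; beyond the scatter), and both rest on the limit of compound 2.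

No direction can be read from these data for a change of furan-3-yl. The expectation in this assay is therefore no step beyond the scatter, with a wide margin on both sides, starting from compound 3 at 9060 nM. The expected step is a 1.3-fold higher number from compound 3 to compound 4 (0.12 log units; within the scatter). For compound 4 the estimated value is 12000 nM, expected to fall between 3000 nM and 45000 nM.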

Compound 4, half-maximal inhibitory concentration: > 20000 nM
Compound 4 gave a limit, no number; the forecaster's own chance of this, stated with the estimate: 45%; middle value at least 1.6-fold (0.22 log units) away from the limit.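

In this assay compound 4 gives > 20000 nM, which is a limit of the assay and not a number. Among the compounds shown here, exchanging furan-3-yl for 1-benzofuran-2-yl gives an at least 2.2-fold higher number from compound 3 to compound 4 (0.34 log units; beyond the scatter), so the aromatic carbon that stayed fixed through all the earlier steps also responds to a change, and here the exchange weakens the compound beyond the scatter. The real size of this step cannot be read, as only its lower bound is available, and compound 4 now shares the ceiling of the series with compound 2: the limit of > 20000 nM in this assay, at which 2 of the 4 values shown sit.

Still open, on these data alone, is whether the loss follows the added six-membered aromatic ring of carbon only or the change in how the furan ring is attached, a question that furan-2-yl at this place would separate. Also open, as far as these compounds go, is whether phenyl, methyl or an aminomethyl chain on this aromatic carbon would give a true number, and whether 1-benzofuran-2-yl behaves the same way with methylsulfanyl in place of dimethylamino.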